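The compounds below may be only part of what the source reports. "The series", "measured", "known", "first", "only" and "open" are said of these compounds alone.

Compound 3, `CNc1nc(Nc2ccccc2)nc(NC2(C#N)CCCCC2)n1`, is one of three measured members of a small group that share one core. In an in vitro assay on Sf21 cells for inhibition of high affinity 3',5'-cyclic-AMP phosphodiesterase 7A (Homo sapiens) (a lower number here means a stronger inhibitor, a higher number a weaker inhibitor), compound 3 gives > 5000 nM, which is a limit of the assay and not a number. Compound 1, `CNc1nc(NC2(C#N)CCCCC2)nc(-n2cccn2)n1`, gives > 5000 nM in this assay, also a limit. Compound 2, `CNc1nc(NC2(C#N)CCCCC2)nc(-n2cncn2)n1`, gives > 5000 nM in this assay, again a limit. Because of the limit of > 5000 nM in this assay, at which 3 of the 3 values shown sit, none of the steps among these three can be sized: a step that the two limits leave unreadable from compound 1 to compound 2, a step that the two limits leave unreadable from compound 1 to compound 3 and a step that the two limits leave unreadable from compound 2 to compound 3 all remain unreadable, so the numbers say only that none of the three reaches a measurable inhibition.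

Compound 4, `CNc1nc(Cl)nc(NC2(C#N)CCCCC2)n1`, differs from compound 3 in one place: chloro in place of anilino on an aromatic carbon. No measured step bears on this change in a readable way; the only guidance is that every compound shown so far sits at the limit, and a smaller group in this position gives no reason to expect a move into the measurable range. Compound 4 is therefore expected to give 10000 nM in this assay, with a plausible range from 3000 nM to 40000 nM. The estimated step that the limit leaves unreadable from compound 3 to compound 4 is expected to be none beyond the scatter, and the assay will most likely report only a limit once more.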

Compound 4, half-maximal inhibitory concentration: 1070 nM
Compound 4: the middle estimate sits 9.3-fold (0.97 log units) above what was measured, and the stated range ends above it.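

The position that carries chloro, anilino or the two azolyl groups does affect inhibition, which the three compounds at the limit could not show. In this assay, the change to chloro gives an at least 4.6-fold lower number from compound 3 to compound 4 (0.66 log units; beyond the scatter), and the same change gives an at least 4.6-fold lower number from compound 2 to compound 4 (0.66 log units; beyond the scatter) and an at least 4.6-fold lower number from compound 1 to compound 4 (0.66 log units; beyond the scatter). Among these four compounds, the only one with no ring at this position is also the only one with a measurable value, and no compound shown goes against this pairing. All three steps are minimum sizes, and the true gaps could be larger, since each starts from a compound whose value is only a limit: the limit of > 5000 nM in this assay, at which 3 of the 4 values shown sit.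

Going by these compounds, it remains open whether chloro itself matters or whether other groups without a ring would serve as well, such as fluoro, methyl, methoxy or a plain amine at this position. On these data alone, all four compounds also carry the same methylamino group, so it is equally open how compound 4 would respond if that group gave way to a longer chain such as propylamino.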